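This account rests on a few compounds, and the source may have more. Where it says the series, first, only, none or still open, it means among the compounds named here.

In a functional assay on the whole organism for antagonist activity, with Mus musculus as the target (on this read-out higher numbers stand for an effect only at larger amounts of compound and lower numbers for an effect already at smaller amounts), compound 1 `COc1cc(N)c(Cl)cc1NC(=O)C1CCN(Cc2cccc(C)c2)CC1` gives 2.4 mg/kg. Compound 2 `CCCCN1CCC(C(=O)Nc2cc(Cl)c(N)cc2OC)CC1` reaches only the limit of the assay, > 10 mg/kg, and not a number. Compound 3 `COc1cc(N)c(Cl)cc1NC(=O)C1CCN(CC2CCCCCC2)CC1` likewise stops at the limit, > 10 mg/kg. Two of the three values thus sit at the limit of > 10 mg/kg in this assay, at which 2 of the 3 values shown sit, and compound 2 stands among them. Compound 4 `CCN1CCC(C(=O)Nc2cc(Cl)c(N)cc2OC)CC1` differs from compound 2 by hydrogen in place of ethyl on a saturated chain carbon, two bonds along the chain from an amine nitrogen in a ring. Within the data shown here, no measured step shortens a chain in this way: the step of an at least 4.1-fold higher number from compound 1 to compound 2 (0.61 log units; beyond the scatter) and the step of an at least 4.1-fold higher number from compound 1 to compound 3 (0.61 log units; beyond the scatter) both replace 3-methylphenyl, and the step that the two limits leave unreadable from compound 2 to compound 3 cannot be read between two limits. Nothing therefore points to a smaller number, so compound 4 is expected to remain near the limit, with an estimated step that the limit leaves unreadable from compound 2 to compound 4. Compound 4 is estimated at 15 mg/kg, expected between 5 mg/kg and 50 mg/kg.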

Compound 4, dose for half-maximal effect: > 10 mg/kg
Compound 4: no number, only a limit; the forecaster's own chance of this, stated with the estimate: 75%; the middle value lies beyond the limit too.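

In this assay compound 4 gives > 10 mg/kg, which is a limit and not a number. Methyl in place of 3-methylphenyl on the saturated chain carbon bound to the ring amine nitrogen gives an at least 4.1-fold higher number from compound 1 to compound 4 (0.61 log units; beyond the scatter), so among the compounds shown only the 3-methylphenyl group yields a measured number, and the small methyl fares no better in this respect than propyl or cycloheptyl: the limit of > 10 mg/kg in this assay, at which 3 of the 4 values shown sit. The steps among compounds 2, 3 and 4 join limits and cannot be read. Going by these compounds, whether a plain phenyl or a 3-chlorophenyl on this carbon would give a number stays open, as does how far compounds 2, 3 and 4 truly differ.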